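The source may report more compounds than this note shows. Statements on the series, on what has been measured and on what is new or still open speak of the compounds shown alone.

Measured compounds:
compound 1 `Cn1c[n+](Cc2ccccc2)c2/c(=N/OC(C)(C)C)[nH]cnc21`: "not determined" (no result reported) in a functional assay on cells (Homo sapiens) for cytotoxicity; on this read-out higher numbers stand for weaker inhibition and lower numbers for stronger inhibition
compound 2 `CO/N=c1\[nH]cnc2c1[n+](C/C=C(\C)CCC=C(C)C)cn2C`: 18400 nM

Within this small set compound 2 stands alone with a number: in this assay compound 2 gives 18400 nM, while compound 1 carries no result at all. Compound 3 `CO/N=c1\[nH]cnc2c1[n+](C/C=C(\C)CC/C=C(\C)CCC=C(C)C)cn2C` differs from compound 2 by 3-methylbut-2-en-1-yl in place of hydrogen on a saturated chain carbon bound to a double-bonded chain carbon. For the measured compounds named here, no step between two measured compounds is available, so the weight of this change cannot be read from the data themselves. For compound 3 a modest shift toward stronger inhibition is expected, a step of a 1.8-fold lower number from compound 2 to compound 3 (0.26 log units; within the scatter) that may well remain within the scatter. Compound 3 is therefore estimated at 10000 nM, with a range from 3000 nM to 40000 nM.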

Compound 3, half-maximal inhibitory concentration: 1240 nM
The estimate for compound 3 lay 8.1-fold (0.91 log units) above the measured number, outside the stated range (below it).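

In this assay, 3-methylbut-2-en-1-yl in place of hydrogen on a saturated chain carbon bound to a double-bonded chain carbon gives a 15-fold lower number from compound 2 to compound 3 (1.17 log units; beyond the scatter) and so lengthens the chain from 2-methylprop-1-en-1-yl to 2,6-dimethylhepta-1,5-dien-1-yl. For the compounds shown here, this gives the first readable step and shows that this place on the chain strongly affects the read-out. Nothing available explains the size of this step. From the compounds shown here alone, it remains open whether a still longer chain would lower the number further. Whether a saturated chain or a terminal carboxylic acid would do the same is also unresolved.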